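A few compounds are considered here, and "the series" means these few. Any claim that something is new, unique, unknown or untested is made for them only; others in the source may bear on it.

Compound 2 `O=C(Nc1cc2cc[nH]c(=O)c2cc1Cl)C1CNCC1c1ccc(F)cc1` gives 9 nM in an assay on isolated protein for inhibition of Rho-associated protein kinase 2 (Homo sapiens), read by a luciferase reporter; on this read-out higher numbers stand for weaker inhibition and lower numbers for stronger inhibition. Among the three measured compounds this is the second highest number: compound 1 `Cc1cccc(C2CNCC2C(=O)Nc2cc3cc[nH]c(=O)c3cc2Cl)c1` gives 5 nM, and the step of a 1.8-fold higher number from compound 1 to compound 2 (0.26 log units; within the scatter) lies within the scatter; compound 3 `O=C(Nc1cc2cc[nH]c(=O)c2cc1Cl)C1(c2ccccc2)CCNC1` gives 240 nM, a far higher number beyond the scatter. Compound 4 `O=C(Nc1cc2cc[nH]c(=O)c2cc1Cl)C1CNCC1c1ccc(Cl)cc1Cl` differs from compound 2 in one place: 2,4-dichlorophenyl in place of 4-fluorophenyl on a saturated ring carbon. Going by the values given here, the only measured step at a saturated ring carbon of this kind is a 1.8-fold higher number from compound 1 to compound 2 (0.26 log units; within the scatter), an exchange of one aryl group for another, and it stayed within the scatter. On that basis only a small step is expected in this assay, with no clear direction. Compound 4 is therefore estimated at 10 nM, with a range from 4 nM to 30 nM, which means an expected step of a 1.1-fold higher number from compound 2 to compound 4 (0.05 log units; within the scatter).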

Compound 4, half-maximal inhibitory concentration: 8 nM
The estimate for compound 4 lay 1.3-fold (0.10 log units) above the measured number; low and high end bracket the measured number.
By their numbers in this assay, from the lowest: compounds 1, 4 and 2 (each within the scatter of the next); then compound 3.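

In this assay, going by these compounds alone, the saturated ring carbon accepts a larger exchange than the earlier compounds showed: two chlorine atoms on the phenyl ring in place of one fluorine leave the number nearly unmoved, with a 1.1-fold lower number from compound 2 to compound 4 (0.05 log units; within the scatter), and a 1.6-fold higher number from compound 1 to compound 4 (0.20 log units; within the scatter). So 3-methylphenyl, 4-fluorophenyl and 2,4-dichlorophenyl cannot be told apart at this position. Nothing available explains why these aryl groups read alike. As far as these compounds go, all three groups are carbon-only aromatic rings, so it remains open whether a phenyl ring carrying an amine or a carboxylic acid would read the same. From the compounds shown here alone, a saturated cyclohexyl ring at this carbon is equally open.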